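The source may report more compounds than this note shows. Statements on the series, on what has been measured and on what is new or still open speak of the compounds shown alone.

Measured compounds:
compound 1, `COc1ccc(-c2cnc3nc(N)nc(N4CCN(C(=O)NCc5ccccc5)CC4)c3n2)cc1OC`: 18 nM
compound 2, `CCOc1nc(N)nc2ncc(-c3ccc(Cl)c(Cl)c3)nc12`: > 10000 nM

Of the compounds shown here, two have been measured in a functional assay on cells (T-cell, Homo sapiens) for inhibition; on this read-out lower numbers stand for stronger inhibition and higher numbers for weaker inhibition. Within the data shown here, compound 1 gives 18 nM and is the only compound for which a number, rather than a limit, is available. Compound 2 is recorded only as a limit in this assay, > 10000 nM, and it therefore marks (the limit of > 10000 nM in this assay, at which 1 of the 2 values shown sits). Among the measured compounds shown here, compound 2 differs from compound 1 in several places at once, so the two values show only that one compound returned a number and the other did not; no single step between them can be read.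

The third compound, compound 3, `COc1ccc(-c2cnc3nc(N)nc(N4CCN(C(=O)COc5ccccc5)CC4)c3n2)cc1OC`, has not yet been measured in this assay. It differs from compound 1 in one place:

phenoxymethyl in place of benzylamino on a carbonyl carbon

Read one bond further out, benzylcarbamoyl becomes (phenoxymethyl)carbonyl, on a carbonyl carbon whose other neighbour is an amide-type nitrogen in a ring. For the measured compounds named here, with no measured step on record to anchor this change, the expectation rests on compound 1 alone, at 18 nM. The step from compound 1 to compound 3 is estimated as a small loss of potency, a 2.8-fold higher number from compound 1 to compound 3 (0.44 log units; beyond the scatter), close to the usual scatter. Compound 3 is therefore expected to give about 50 nM in this assay, within a range of 15 nM to 200 nM.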

Compound 3, half-maximal inhibitory concentration: 4 nM
Beside the measured number, compound 3's estimate is 13-fold (1.10 log units) above it, and the stated range ends above it.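

In this assay, the step at this place on the carbonyl carbon, whose other neighbour is an amide-type nitrogen in a ring, favours the new group: phenoxymethyl in place of benzylamino gives a 4.5-fold lower number from compound 1 to compound 3 (0.65 log units; beyond the scatter). Benzylamino counts a hydrogen-bond donor and phenoxymethyl none, yet compound 3 gives the lower number, so with this core a donor in this group is not required for strong inhibition on this read-out, and the place accepts a carbonyl substituent with no nitrogen in it. Nothing shown explains why the step runs in this direction or why it has this size.

The two groups share the same count of heavy atoms and the same aromatic ring of carbon only, but they differ both in nitrogen against oxygen and in the order of the atoms in the link, and this single step cannot separate those two differences. The compounds shown also leave open how the number would respond to a longer chain such as phenoxyethyl, to a plain benzyl group on the carbonyl, or to a fluorine or a methoxy group on the phenoxy ring.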